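Fluoro to chloro on the aryl group of compound 3

The source may hold more compounds than are shown below. What is called first, only, known or untested is meant among the compounds shown, and "the series" means these compounds.

In a functional assay on the whole organism (strain Swiss) with Mus musculus as the target, in the maximal electroshock model, with a stated time of 2 h, at a dose of 300 mg/kg by the intraperitoneal route (a higher number here means a stronger effect of the compound at the dose given, a lower number a weaker effect), compound 1 `CC(C(=O)N1CCN(c2cccc(Cl)c2)CC1)N1C(=O)CCC1=O` gives 50% and compound 2 `CC(C(=O)N1CCN(c2ccc(F)cc2)CC1)N1C(=O)CCC1=O` gives 50%, the pair showing no change at the digits printed from compound 1 to compound 2 (within the scatter). Compound 3 `CC(C(=O)N1CCN(c2ccccc2F)CC1)N1C(=O)CCC1=O` gives 25%, the lowest of the three numbers: a number 25 percentage points lower from compound 1 to compound 3 (beyond the scatter) and a number 25 percentage points lower from compound 2 to compound 3 (beyond the scatter) both set it apart beyond the scatter. Compound 4 `CC(C(=O)N1CCN(c2ccccc2Cl)CC1)N1C(=O)CCC1=O` differs from compound 3 by chloro in place of fluoro on an aromatic carbon; the same difference, cut one bond further out, reads 2-fluorophenyl to 2-chlorophenyl. Going by the values given here, no measured step swaps fluoro for chloro on the same aromatic carbon. The nearest evidence is the step from compound 1 to compound 2, where 3-chlorophenyl against 4-fluorophenyl stayed within the scatter, while both steps into compound 3 changed the halogen and its place together, so they do not separate the two. A small step is therefore expected, a number 5 percentage points higher from compound 3 to compound 4 (within the scatter), within the scatter or marginally upward. Compound 4 is estimated at 30% with a range of 0% to 60%.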

Compound 4, a percentage reported as activity, at one dose (the size of the read-out at that dose, not a potency): 0%
Estimate against measurement, compound 4: 30 percentage points above; the range from low to high includes it.
By their numbers in this assay, from the lowest: compound 4; then compound 3; then compounds 1 and 2 (each within the scatter of the next).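

Chloro in place of fluoro on an aromatic carbon ortho to a large group gives a number 25 percentage points lower from compound 3 to compound 4 (beyond the scatter) in this assay, the first step in the series that changes the halogen while its place stays fixed, so the identity of the halogen matters at this position. The step with the halogen held and its place changed, 2-chlorophenyl in place of 3-chlorophenyl, gives a number 50 percentage points lower from compound 1 to compound 4 (beyond the scatter), and 2-chlorophenyl in place of 4-fluorophenyl gives a number 50 percentage points lower from compound 2 to compound 4 (beyond the scatter), which leaves compound 4 the weakest of the four at this single dose. Nothing measured here accounts for these steps.

From the compounds shown here alone, whether chloro and fluoro differ in the same way elsewhere on the ring remains open, as a comparison of 3-chlorophenyl with 3-fluorophenyl would show. Also open, going by these compounds, is how a 2-methylphenyl, 2-methoxyphenyl or unsubstituted phenyl group would read in this model.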